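The compounds below may be only part of what the source reports. "The series", "measured", "known", "first", "only" and "open" are said of these compounds alone.

The series shares one core. Compound 1 `CCCCCc1ccc2nc(N)sc2c1` in a functional assay on the whole organism with Rattus norvegicus as the target (on this read-out lower numbers stand for an effect already at smaller amounts and higher numbers for an effect only at larger amounts of compound), gives 7.5 mg/kg. Compound 2 `CC(C)(C)Cc1ccc2nc(N)sc2c1` in this assay reaches only a limit of the assay, > 10 mg/kg. The step of an at least 1.3-fold higher number from compound 1 to compound 2 (0.12 log units; that floor lies within the scatter) can therefore be sized only at its floor, which rests on (the limit of > 10 mg/kg in this assay, at which 1 of the 3 values shown sits). Compound 3 `CCN(CC)C(=O)Cn1c(=N)sc2cc(OC(F)(F)F)ccc21` in this assay gives 9 mg/kg; of the two numbers in the set, the value of compound 3 and that of compound 1 lie within the scatter of each other. The third entry, that of compound 2, is a limit of the assay and stands apart.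

Compound 4 `CNCCn1c(=N)sc2cc(OC(F)(F)F)ccc21` is not yet measured. It differs from compound 3 in one place: (methylamino)methyl in place of diethylcarbamoyl on a saturated chain carbon bound to an aromatic nitrogen. Among the measured compounds shown here, the single measured step, an at least 1.3-fold higher number from compound 1 to compound 2 (0.12 log units; that floor lies within the scatter), concerns a saturated chain carbon bound to an aromatic carbon and does not touch the saturated chain carbon bound to an aromatic nitrogen, so it gives no guide to the present change. For the measured compounds named here, no pair exchanges a diethylcarbamoyl for a (methylamino)methyl group. Without a comparable step, the expectation for compound 4 is a value close to that of compound 3, with no step beyond the scatter, the expected step being no change at the digits printed from compound 3 to compound 4 (within the scatter). Compound 4 is estimated at 9 mg/kg, within a range from 4 mg/kg to 20 mg/kg.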

Compound 4, dose for half-maximal effect: > 10 mg/kg
Compound 4: a limit, no number; the forecaster's own chance of this, stated with the estimate: 25%; at least 1.1-fold (0.04 log units) between middle value and limit.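

In this assay, among the compounds shown here, the replacement of diethylcarbamoyl by (methylamino)methyl on a saturated chain carbon bound to an aromatic nitrogen gives the first step at this place, an at least 1.1-fold higher number from compound 3 to compound 4 (0.04 log units; that floor lies within the scatter). The result for compound 4 is a limit of the assay and not a number, so this step has a floor but no measured size, and it may lie within the scatter or beyond it. What the position does show is that this change gives no lower number, although the reading of the step is bounded by the top of the read-out, which now holds a second compound of the series: the limit of > 10 mg/kg in this assay, at which 2 of the 4 values shown sit.

The compounds shown leave open what number lies behind the limit of compound 4, and whether the result follows from the loss of the diethylcarbamoyl group or from the arrival of the (methylamino)methyl group. On these data alone, how a carboxylic acid or a dimethylamino group at the same place would read in this assay also remains open.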